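This account rests on a few compounds, and the source may have more. Where it says the series, first, only, none or still open, it means among the compounds named here.

Measured in a functional assay on MCF7 cells (Homo sapiens) for inhibition, read by MTT assay, with a stated time of 72 h; on this read-out higher numbers stand for weaker inhibition and lower numbers for stronger inhibition:
- compound 1 `CC(C)(C)OC(=O)N1CCN(c2cc(C(F)(F)F)nc(SCc3ccc(C(F)(F)F)cc3)n2)CC1`: > 50000 nM
- compound 2 `FC(F)(F)c1ccc(CSc2nc(N3CCN(c4ccccn4)CC3)cc(C(F)(F)F)n2)cc1`: > 50000 nM
- compound 3 `Cc1csc(Sc2cc(C(F)(F)F)nc(SCc3ccc(C(F)(F)F)cc3)n2)n1`: 14500 nM

Compound 1 gives > 50000 nM, which is a limit and not a number. Compound 2 gives > 50000 nM, again a limit. That leaves compound 3, at 14500 nM, as the only one of the three with an actual number in this assay.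

The next compound to be tested is compound 4 `FC(F)(F)c1ccc(CSc2nc(Sc3nncs3)cc(C(F)(F)F)n2)cc1`. It keeps the rest of compound 3 and changes one group on a sulfur, with 1,3,4-thiadiazol-2-yl in place of 4-methyl-1,3-thiazol-2-yl on a sulfur.

The measurements offer little guidance for this change. Going by the values given here, the only measured step, a step that the two limits leave unreadable from compound 1 to compound 2, involves different groups, and it has no readable size to carry over. Among the compounds with values here, with no measured step to draw on, no change beyond the usual scatter is expected in this assay, and no direction can be favoured. A result reported only as a limit remains possible, given (the limit of > 50000 nM in this assay, at which 2 of the 3 values shown sit). The expected step is a 1.1-fold higher number from compound 3 to compound 4 (0.04 log units; within the scatter). Compound 4 is estimated at 16000 nM, with an expected range of 5000 nM to 45000 nM.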

Compound 4, half-maximal inhibitory concentration: 8810 nM
Estimate against measurement, compound 4: 1.8-fold (0.26 log units) above; measured number inside the range.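

In this assay, going by these compounds alone, replacing 4-methyl-1,3-thiazol-2-yl with 1,3,4-thiadiazol-2-yl on the sulfur gives a 1.6-fold lower number from compound 3 to compound 4 (0.22 log units; within the scatter), and this is the first step whose size can be read, since the limits on the earlier step leave it unreadable. The sulfur position therefore accepts this swap of one five-membered aromatic ring for another without a change beyond the scatter, even though the entering ring has one more hetero atom and one fewer heavy atom. No measurement shown here offers a cause for this result, and a step of this size gives none to explain.

The swap removes the methyl group and adds a ring nitrogen in one move, so the plain 1,3-thiazol-2-yl group, without the methyl, would be needed to tell the two parts apart. Also open, on these data alone, is how far this acceptance extends on the sulfur, for instance to a six-membered ring such as pyridine, a longer chain without a ring, or a chain ending in a carboxylic acid.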